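Pyridin-2-yl for phenyl on the ring nitrogen: compound 4

The source may hold more compounds than are shown below. What is called first, only, known or untested is meant among the compounds shown, and "the series" means these compounds.

Measured so far:
compound 1 `Nc1c2c(=O)[nH]c(-c3ccccc3)cc2nn1-c1ccccc1` 23%
compound 2 `COc1ccccc1-c1cc2nn(-c3ccccc3)c(N)c2c(=O)[nH]1` 20%
compound 3 `COc1ccc(-c2cc3nn(-c4ccccc4)c(N)c3c(=O)[nH]2)cc1` 28%

In an assay on isolated protein for inhibition of serine/threonine-protein kinase D2 (Homo sapiens), read by mobility shift assay, tested at 30 uM (on this read-out higher numbers stand for more inhibition at the one concentration tested (going by the name of the read-out) and lower numbers for less inhibition), compound 1 gives 23%, the second highest of the three numbers. Compound 2 sits nearest with 20%. Compound 3 is furthest with 28%. All three lie within the scatter of one another: a number 3 percentage points lower from compound 1 to compound 2 (within the scatter), a number 5 percentage points higher from compound 1 to compound 3 (within the scatter), a number 8 percentage points higher from compound 2 to compound 3 (within the scatter). Each of these steps concerns a methoxy on the aryl group that sits on an aromatic carbon of the shared core.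

Compound 4 `Nc1c2c(=O)[nH]c(-c3ccccc3)cc2nn1-c1ccccn1` is not yet measured in this assay. It differs from compound 1 in one place: pyridin-2-yl in place of phenyl on an aromatic nitrogen. Among the compounds with values here, none of the measured steps touches this position, so no step bears on the change directly; the measured series only shows that variation of the other aryl group left the read-out within the scatter. The estimated step of no change at the digits printed from compound 1 to compound 4 (within the scatter) is therefore expected to stay within the scatter, with no direction favoured. Compound 4 is expected to give 23%, between 8% and 40%.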

Compound 4, a percentage reported as inhibition, at one concentration (the size of the read-out at that concentration, not a potency): 16%
Beside the measured number, compound 4's estimate is 7 percentage points above it, within the range that was stated.
By their numbers in this assay, from the lowest: compounds 4, 2, 1 and 3 (each within the scatter of the next, the first and the last beyond it).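

Within the data shown here, the aryl group on the aromatic nitrogen now has a first reading in this assay: with pyridin-2-yl in place of phenyl, the step is a number 7 percentage points lower from compound 1 to compound 4 (within the scatter). This position therefore accepts a ring nitrogen and the hydrogen-bond acceptor counted on pyridin-2-yl without a step beyond the scatter, as the methoxy changes on the other aryl group also did. Nothing at hand explains the size or direction of this step.

The compounds shown leave open whether the number in this assay would be higher, lower or level with substituents on this nitrogen other than six-membered aromatic rings, such as a cyclohexyl or benzyl group, or a phenyl carrying a carboxylic acid. They also leave open whether any change to the amino group on the shared core, such as an acetamide in its place, would move the read-out beyond the scatter.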